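Trifluoromethyl for trifluoromethoxy on the shared core

The source may hold more compounds than are shown below. What is called first, only, known or untested is meant among the compounds shown, and "the series" means these compounds.

Measured so far:
compound 1 `O=C(Nc1ccc(OC(F)(F)F)cc1)NC1CCN(C(=O)[C@@H]2CCOC2)CC1` — in a physicochemical assay for lipophilicity, read by HPLC, with a stated time of 90 min, tested at 100 uM (a lower number here means a more polar compound, a higher number a more lipophilic compound), compound 1 gives 3.38
compound 2 `O=C(Nc1ccc(C(F)(F)F)cc1)NC1CCN(C(=O)C2CCOC2)CC1` — in this assay compound 2 gives 3.16
compound 3 `O=C(Nc1ccc(OC(F)(F)F)cc1)NC1CCN(C(=O)c2cc[nH]c2)CC1` — in this assay compound 3 gives 3.34

Compound 3 stands second highest of the three numbers; its nearest neighbour is compound 1, its furthest compound 2, and both gaps lie within the scatter, so no order among the three can be read. For the measured compounds named here, the one measured step, a number 0.04 log units lower from compound 1 to compound 3 (within the scatter), concerns the group on the carbonyl carbon and does not bear on the change now at hand.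

Compound 4 `O=C(Nc1ccc(C(F)(F)F)cc1)NC1CCN(C(=O)c2cc[nH]c2)CC1` differs from compound 3 by trifluoromethyl in place of trifluoromethoxy on an aromatic carbon. Going by the values given here, no measured step isolates this change. Compounds 1 and 2 differ in the same way and in one further place, compound 1 at 3.38 and compound 2 at 3.16; what the two values show is a small gap within the scatter, with the trifluoromethyl compound lower. A step of similar size downward, or none beyond the scatter, is therefore expected in this assay. The expected step is a number 0.19 log units lower from compound 3 to compound 4 (within the scatter). Compound 4 is estimated at 3.15, between 2.85 and 3.45.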

Compound 4, partition coefficient: 3.26
Compound 4: the middle estimate sits 0.11 log units below what was measured; measured number inside the range.
By their numbers in this assay, from the lowest: compounds 2, 4, 3 and 1 (each within the scatter of the next).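

In this assay, the step of a number 0.08 log units lower from compound 3 to compound 4 (within the scatter) now isolates trifluoromethyl in place of trifluoromethoxy on an aromatic carbon para to a large group, and the change stays within the scatter with 1H-pyrrol-3-yl on the carbonyl carbon. The step of a number 0.10 log units higher from compound 2 to compound 4 (within the scatter) shows 1H-pyrrol-3-yl in place of oxolan-3-yl with trifluoromethyl on the aromatic ring, and like a number 0.04 log units lower from compound 1 to compound 3 (within the scatter) it gives no difference that can be read beyond the scatter. No evidence on the origin of these small steps is at hand.

Across the compounds shown, neither place has yet produced a step beyond the scatter in this assay. Still open, on these data alone, is whether an amine or a carboxylic acid on the aromatic carbon, or a longer chain on the carbonyl carbon, would do so.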